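A few compounds are considered here, and "the series" means these few. Any claim that something is new, unique, unknown or untested is made for them only; others in the source may bear on it.

Compound 1 `OC[C@H]1O[C@@H](n2cc(F)c3c(-c4cccs4)ncnc32)[C@H](O)[C@@H]1O` gives 4300 nM
Compound 2 `OC[C@H]1O[C@@H](n2cc(F)c3c(-c4ccsc4)ncnc32)[C@H](O)[C@@H]1O` gives 210 nM
Compound 3 `OC[C@H]1O[C@@H](n2cc(Cl)c3c(-c4cccs4)ncnc32)[C@H](O)[C@@H]1O` gives 28200 nM

a functional assay on HeLa S3 cells (Homo sapiens) for cytotoxicity, read by XTT assay, with a stated time of 3 days (on this read-out lower numbers stand for stronger inhibition and higher numbers for weaker inhibition), is the source of all three numbers. Compound 3 has the highest number of the three and is the weakest inhibitor here, with its gaps to both others beyond the scatter.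

Compound 4 `OC[C@H]1O[C@@H](n2cc(Cl)c3c(-c4ccsc4)ncnc32)[C@H](O)[C@@H]1O` has not yet been measured. It keeps the chloro group of compound 3 but carries thiophen-3-yl in place of thiophen-2-yl on an aromatic carbon and nothing else changes.

The same swap among the fluoro compounds gave a 20-fold lower number from compound 1 to compound 2 (1.31 log units; beyond the scatter), a large drop. Chloro in place of fluoro gave a 6.6-fold higher number from compound 1 to compound 3 (0.82 log units; beyond the scatter), a modest rise, so the halogen matters too. For the measured compounds named here, only a single pair shows the swap, and it may not carry over at full size to the chloro compounds.

A large step to a lower number is still expected, an estimated 20-fold lower number from compound 3 to compound 4 (1.30 log units; beyond the scatter) in this assay overall. Compound 4 is estimated at 1400 nM, with 350 nM to 6000 nM as the expected range.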

Compound 4, half-maximal inhibitory concentration: 340 nM
Beside the measured number, compound 4's estimate is 4.1-fold (0.61 log units) above it, outside the stated range (below it).
By their numbers in this assay, from the lowest: compounds 2 and 4 (each within the scatter of the next); then compound 1; then compound 3.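

In this assay, thiophen-3-yl in place of thiophen-2-yl also lowers the number when the chloro group is present, giving an 83-fold lower number from compound 3 to compound 4 (1.92 log units; beyond the scatter), so this swap now holds on two cores and its size depends on the halogen: the same change on two cores in this assay, a 20-fold lower number (1.31 log units; beyond the scatter) from compound 1 to compound 2 and an 83-fold lower number (1.92 log units; beyond the scatter) from compound 3 to compound 4, 4.1-fold (0.61 log units) apart, beyond the scatter of two such steps The halogen's influence depends in turn on the thiophene: with thiophen-3-yl, chloro in place of fluoro gives a 1.6-fold higher number from compound 2 to compound 4 (0.21 log units; within the scatter), unlike the clear rise seen with thiophen-2-yl: the same change on two cores in this assay, a 6.6-fold higher number (0.82 log units; beyond the scatter) from compound 1 to compound 3 and a 1.6-fold higher number (0.21 log units; within the scatter) from compound 2 to compound 4, 4.1-fold (0.61 log units) apart, beyond the scatter of two such steps Across these compounds, then, the two changes do not simply add up.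

From the compounds shown here alone, it remains open whether a phenyl or furan-3-yl group in the thiophene's place, or a bromo or methyl group in the halogen's place, would follow the same pattern. These numbers also cannot tell why the two changes depend on each other.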